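The compounds below may be only part of what the source reports. "The series", "measured", "known", "first", "only" and "open" are said of these compounds alone.

Compound 2 `C[C@H]1[C@H](NCc2cncs2)C[C@H]2C[C@@H]1C2(C)C` is known in an ADME assay on MDCK cells (Canis lupus familiaris) for cytotoxicity, read by microscopy, with a stated time of 48 h (on this read-out lower numbers stand for higher toxicity in this test and higher numbers for lower toxicity in this test), only as a limit: compound 2 gives > 100000 nM. That places compound 2 at the limit of > 100000 nM in this assay, at which 1 of the 2 values shown sits. Compound 3 `Cc1csc(CN[C@@H]2C[C@H]3C[C@@H]([C@H]2C)C3(C)C)c1` differs from it in one place: 4-methylthiophen-2-yl in place of 1,3-thiazol-5-yl on a saturated chain carbon bound to an amine nitrogen. Within the data shown here, the single measured step that bears on this is the opposite exchange, which gave an at least 2.0-fold higher number from compound 1 to compound 2 (0.30 log units; that floor lies within the scatter), where compound 1 `C[C@H]1[C@H](NCc2sccc2Br)C[C@H]2C[C@@H]1C2(C)C` gives 50000 nM. Putting a 4-methylthiophen-2-yl group back in place of 1,3-thiazol-5-yl is therefore expected to move the number back toward that of compound 1, though a limit is again quite possible. For compound 3 the estimate is 70000 nM, with a range from 30000 nM to 200000 nM, meaning an expected step of an at least 1.4-fold lower number from compound 2 to compound 3 (0.15 log units; that floor lies within the scatter).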

Compound 3, minimum cytotoxic concentration: 12500 nM
Compound 3: middle estimate off by 5.6-fold (0.75 log units), on the high side, outside the stated range (below it).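

In this assay, the group on this saturated chain carbon clearly matters: the exchange gives an at least 8.0-fold lower number from compound 2 to compound 3 (0.90 log units; beyond the scatter), whereas the earlier floor lay within the scatter. Even replacing one substituted thiophene with another has a real effect, giving a 4.0-fold lower number from compound 1 to compound 3 (0.60 log units; beyond the scatter).

On these data alone, whether the methyl group or the thiophene ring accounts for the lower number stays open, as does how a plain phenyl group would read at this place. The full size of the step from the thiazole also stays open because compound 2 is known only as a limit: the limit of > 100000 nM in this assay, at which 1 of the 3 values shown sits.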